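This account rests on a few compounds, and the source may have more. Where it says the series, first, only, none or still open, it means among the compounds named here.

Compounds measured in a functional assay on BMMC cells (Mus musculus, strain C57BL/6) for inhibition, with stated times of 5 days and 48 h; on this read-out higher numbers stand for weaker inhibition and lower numbers for stronger inhibition:
compound 1 `C=C1CC[C@@H]2[C@](C)(CO)[C@H](O)CC[C@@]2(C)[C@@H]1CC=O` — > 30000 nM.
compound 2 `C=C1CC[C@@H]2[C@](C)(CNCc3cccc(OC)c3)[C@H](O)CC[C@@]2(C)[C@@H]1/C=C/C1=CCOC1=O` — 780 nM.
compound 3 `C=C1CC[C@@H]2[C@](C)(CNCc3ccc(OC)c(OC)c3)[C@H](O)CC[C@@]2(C)[C@@H]1/C=C/C1=CCOC1=O` — 3740 nM.

The value of compound 1, > 30000 nM, is a limit of this assay and not a number, as the limit of > 30000 nM in this assay, at which 1 of the 3 values shown sits, records. Among the two numbers, compound 3 stands highest: the nearest is compound 2, whose value 780 nM lies a clear step lower, as the step of a 4.8-fold higher number from compound 2 to compound 3 (0.68 log units; beyond the scatter) shows, arising from methoxy in place of hydrogen on an aromatic carbon.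

Compound 4 `C=C1CC[C@@H]2[C@](C)(CNCc3ccco3)[C@H](O)CC[C@@]2(C)[C@@H]1/C=C/C1=CCOC1=O` differs from compound 3 by furan-2-yl in place of 3,4-dimethoxyphenyl on a saturated chain carbon bound to an amine nitrogen. Going by the values given here, the only measured step bearing on this change is a 4.8-fold higher number from compound 2 to compound 3 (0.68 log units; beyond the scatter), where adding a methoxy raised the number beyond the scatter. Replacing 3,4-dimethoxyphenyl by furan-2-yl removes both methoxy groups, so a move back toward the region of compound 2 is expected, though the new ring is itself a further change. Compound 4 is therefore expected to show a 2.9-fold lower number from compound 3 to compound 4 (0.46 log units; beyond the scatter), estimated at 1300 nM with a range from 400 nM to 4500 nM.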

Compound 4, half-maximal inhibitory concentration: 1830 nM
The estimate for compound 4 lay 1.4-fold (0.15 log units) below the measured number; the range from low to high includes it.
By their numbers in this assay, from the lowest: compound 2; then compound 4; then compound 3. At a limit, above all of these: compound 1.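

In this assay, replacing the six-membered carbon ring with a five-membered aromatic ring with 1 hetero atom gives a number inside the span of the two methoxy-bearing phenyl compounds, with a 2.0-fold lower number from compound 3 to compound 4 (0.31 log units; beyond the scatter) and a 2.3-fold higher number from compound 2 to compound 4 (0.37 log units; beyond the scatter). Earlier, only methoxy count on a phenyl ring had varied at this place; now a ring carrying no methoxy at all also stays within that span, while the 3-methoxyphenyl of compound 2 keeps the lowest number of the three. Nothing shown here accounts for this order of the three rings.

The compounds shown leave open where an unsubstituted phenyl or a pyridine ring would stand at this place. Compound 4 also differs in ring size and hetero atom at once, so these two changes cannot be told apart.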